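Varying the benzyl substituent: what to expect for compound 4

The source may report more compounds than this note shows. Statements on the series, on what has been measured and on what is new or still open speak of the compounds shown alone.

Compound 1, `COc1cccc(OC)c1OCCNCCOc1ccccc1OCc1ccccc1Cl`: 5400 nM in a functional assay on PC-3 cells (Homo sapiens) for cytotoxicity, read by sulforhodamine B assay; on this read-out higher numbers stand for weaker inhibition of growth and lower numbers for stronger inhibition of growth
Compound 2, `COc1cccc(OC)c1OCCNCCOc1ccccc1OCc1cccc(Cl)c1`: 5900 nM
Compound 3, `COc1cccc(OC)c1OCCNCCOc1ccccc1OCc1ccc(C)cc1`: 7800 nM

Compound 1 gives the lowest number of the three, yet its steps to the others, a 1.1-fold higher number from compound 1 to compound 2 (0.04 log units; within the scatter) and a 1.4-fold higher number from compound 1 to compound 3 (0.16 log units; within the scatter), both lie within the scatter, as does a 1.3-fold higher number from compound 2 to compound 3 (0.12 log units; within the scatter), so the three compounds cannot be ordered. Compound 4, `COc1cccc(OC)c1OCCNCCOc1ccccc1OCc1ccc(OC(C)C)cc1`, differs from compound 1 in that (4-isopropoxyphenyl in place of 2-chlorophenyl on a saturated chain carbon bound to an oxygen on an aromatic ring). The three measured steps, each a swap of the substituent on this phenyl, all stayed within the scatter, and nothing else is known about this position. Compound 4 is therefore expected to show a 1.2-fold higher number from compound 1 to compound 4 (0.08 log units; within the scatter), no step beyond the scatter. Compound 4 is estimated at 6500 nM, with a range from 3000 nM to 14000 nM.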

Compound 4, concentration for 50% growth inhibition: 2000 nM
Compound 4: the middle estimate sits 3.3-fold (0.51 log units) above what was measured; measured number outside the range, below it.
By their numbers in this assay, from the lowest: compound 4; then compounds 1, 2 and 3 (each within the scatter of the next).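

Unlike the earlier swaps, this change moves the number beyond the scatter in this assay, with a 2.7-fold lower number from compound 1 to compound 4 (0.43 log units; beyond the scatter) and a 3.0-fold lower number from compound 2 to compound 4 (0.47 log units; beyond the scatter) against the chlorinated compounds. The one-group comparison, isopropoxy in place of methyl on an aromatic carbon, gives a 3.9-fold lower number from compound 3 to compound 4 (0.59 log units; beyond the scatter) and shows that this position can respond to the group it carries.

Going by these compounds, whether an ethoxy, a butoxy or a dimethylamino group in place of the isopropoxy would lower the number as well remains open. No evidence at hand explains the change.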